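Changing the ring on the ether oxygen of compound 3

The source may report more compounds than this note shows. Statements on the series, on what has been measured and on what is new or still open speak of the compounds shown alone.

Compound 1 `Cc1ccncc1C(=O)N1CC(Oc2cncc(N3C(=O)c4ccc(Cl)cc4C3(C)C)c2)C1`: 4 nM
Compound 2 `CC1(C)c2cc(Cl)ccc2C(=O)N1c1cncc(OC2CN(C(=O)c3ncccc3Cl)C2)c1`: 5 nM
Compound 3 `CC(=O)N1CCC(Oc2cncc(N3C(=O)c4ccc(Cl)cc4C3(C)C)c2)CC1`: 4 nM

All three compounds were measured in an assay on cells for inhibition of cytochrome P450 11B2, mitochondrial (Homo sapiens), read by HTRF; a lower number here means a stronger inhibitor, a higher number a weaker inhibitor. Compound 3 stands level with compound 1 at the digits shown, and the two share the lowest number of the three; compound 2 is the farthest from compound 3, but the gap is within the usual scatter, so no compound can be called stronger or weaker than another on these numbers.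

Among the compounds with values here, only one step between measured compounds differs in a single place: a 1.3-fold higher number from compound 1 to compound 2 (0.10 log units; within the scatter). It alters the group on the carbonyl carbon and stays within the scatter. It does not touch the part of the molecule changed here.

Compound 4 `CCS(=O)(=O)N1CC(Oc2cncc(N3C(=O)c4ccc(Cl)cc4C3(C)C)c2)C1` differs from compound 3 in one place: a group of 9 heavy atoms (5 carbon, 1 nitrogen, 2 oxygen, 1 sulfur; one four-membered non-aromatic ring with 1 hetero atom) in place of a group of 9 heavy atoms (7 carbon, 1 nitrogen, 1 oxygen; one six-membered non-aromatic ring with 1 hetero atom), on an oxygen on an aromatic ring. Compound 1 and compound 3 show that a four-membered ring carrying an aromatic amide and a six-membered ring carrying an acetyl give the same number at the digits shown, so the change of ring size on its own has not moved the result in this series. Within the data shown here, no measured step covers the rest of the change, so the expectation rests on that single comparison and carries real uncertainty. The step expected is a 1.5-fold higher number from compound 3 to compound 4 (0.18 log units; within the scatter), that is, nothing beyond the scatter. For compound 4 the estimate is 6 nM, with a range from 2 nM to 20 nM.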

Compound 4, half-maximal inhibitory concentration: 4 nM
Compound 4: middle estimate off by 1.5-fold (0.18 log units), on the high side, and the stated range covers the measured number.
By their numbers in this assay, from the lowest: compounds 1, 3, 4 and 2 (each within the scatter of the next).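

In this assay, replacing the 1-acetylpiperidin-4-yl group on an oxygen on an aromatic ring with a four-membered non-aromatic ring carrying ethylsulfonyl gives no change at the digits printed from compound 3 to compound 4 (within the scatter) even though ring size and the group on the ring nitrogen differ together. Comparing compounds with the same four-membered ring isolates the group on that amine nitrogen: ethylsulfonyl in place of (4-methylpyridin-3-yl)carbonyl gives no change at the digits printed from compound 1 to compound 4 (within the scatter) and ethylsulfonyl in place of (3-chloropyridin-2-yl)carbonyl gives a 1.3-fold lower number from compound 2 to compound 4 (0.10 log units; within the scatter) in this assay. Compound 4 thus shows that, among these compounds, a carbonyl on the ring nitrogen is not needed to keep the number within the scatter of the others, since a sulfonyl group serves equally well there.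

From the compounds shown here alone, all four compounds still carry a carbonyl or sulfonyl group on that nitrogen, so it remains open how a free amine, or a longer chain ending in a carboxylic acid, would read in this assay. No measurement here explains why these different groups give matching numbers.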